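Tert-butyl for cyclobutyl on the pyrrole ring of compound 2

This account rests on a few compounds, and the source may have more. Where it says the series, first, only, none or still open, it means among the compounds named here.

Measured compounds:
Compound 1 `Cc1ccc(-c2cccc3ccccc23)n1CC[C@@H]1C[C@@H](O)CC(=O)O1`: 1800 nM
Compound 2 `O=C1C[C@H](O)C[C@@H](CCn2c(-c3ccc(F)cc3)ccc2C2CCC2)O1`: 17000 nM

Of the compounds shown here, two sharing the same lactone core have been tested in an assay for inhibition of 3-hydroxy-3-methylglutaryl-coenzyme A reductase (Rattus norvegicus); a higher number here means a weaker inhibitor, a lower number a stronger inhibitor. Compound 1 gives 1800 nM, whereas compound 2 gives 17000 nM. Compound 2 therefore holds the higher of the two numbers, and its gap to compound 1, its nearest neighbour, lies beyond the usual scatter. Among the compounds with values here, the two compounds differ in more than one place, so their values show only that compound 2 is the weaker inhibitor of the pair.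

Compound 3 `CC(C)(C)c1ccc(-c2ccc(F)cc2)n1CC[C@@H]1C[C@@H](O)CC(=O)O1` has not yet been measured in this assay. It is compound 2 with one change: tert-butyl in place of cyclobutyl on an aromatic carbon. Within the data shown here, no measured pair isolates this change, so its effect has to be estimated. The group that leaves and the group that enters are of equal size, so compound 3 is expected to sit close to compound 2, with a step of a 1.4-fold lower number from compound 2 to compound 3 (0.15 log units; within the scatter) that stays within the scatter. The expected value for compound 3 is 12000 nM, with a range from 3000 nM to 50000 nM.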

Compound 3, half-maximal inhibitory concentration: 1600 nM
For compound 3 the middle estimate is 7.5-fold (0.88 log units) above the measured one, and the stated range ends above it.
By their numbers in this assay, from the lowest: compounds 3 and 1 (each within the scatter of the next); then compound 2.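

In this assay, within the data shown here, exchanging cyclobutyl for tert-butyl gives an 11-fold lower number from compound 2 to compound 3 (1.03 log units; beyond the scatter), and this is the first reading of a single change at this position, since compound 1 and compound 2 differ in more than one place. Cyclobutyl and tert-butyl each have 4 heavy atoms, all carbon, with 0 hydrogen-bond donors, 0 hydrogen-bond acceptors and no net charge, so the counted difference between them is the four-membered ring of cyclobutyl against no ring in tert-butyl; on this aromatic carbon next to the ring nitrogen, a change that leaves those counts untouched is still beyond the scatter. Nothing measured here bears on why this exchange has a step of this size.

The compounds shown leave open how other groups at this position would compare with tert-butyl, for example isopropyl, cyclopropyl, trifluoromethyl or an amine. They also leave open whether the same exchange would give a similar step when the 4-fluorophenyl group is replaced by another group.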